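A few compounds are considered here, and "the series" means these few. Any claim that something is new, unique, unknown or untested is made for them only; others in the source may bear on it.

Compound 1 `Cc1cccc(C)c1NC(=O)/C=C/C(=O)N1C/C(=C\c2ccc([N+](=O)[O-])cc2)C(=O)/C(=C/c2ccc([N+](=O)[O-])cc2)C1` is the stronger of the two measured compounds in a functional assay on L1210 cells (Mus musculus) for cytotoxicity; on this read-out lower numbers stand for stronger inhibition and higher numbers for weaker inhibition. In this assay compound 1 gives 690 nM. Compound 2 `Cc1ccc(NC(=O)/C=C/C(=O)N2C/C(=C\c3ccccc3)C(=O)/C(=C/c3ccccc3)C2)cc1` differs from compound 1 in several places. In this assay compound 2 gives 5800 nM, a weaker result than that of compound 1 and beyond the usual scatter. Compound 2 differs in two places at once. Its numbers say nothing separately about either change.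

Compound 3 `COc1ccc(NC(=O)/C=C/C(=O)N2C/C(=C\c3ccc([N+](=O)[O-])cc3)C(=O)/C(=C/c3ccc([N+](=O)[O-])cc3)C2)cc1` has not yet been measured. It differs from compound 1 in one place: 4-methoxyphenyl in place of 2,6-dimethylphenyl on an amide-type nitrogen. Within the data shown here, no single-change step between measured compounds bears on this exchange, so the only guide is the distance between compound 1 and compound 2.

The expectation for compound 3 in this assay is a small shift toward weaker inhibition, possibly no larger than the scatter, with a step from compound 1 estimated at a 2.0-fold higher number from compound 1 to compound 3 (0.31 log units; beyond the scatter). Compound 3 is therefore estimated at 1400 nM in this assay, within a range from 400 nM to 5000 nM.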

Compound 3, half-maximal inhibitory concentration: 2900 nM
Compound 3: middle estimate off by 2.1-fold (0.32 log units), on the low side, within the range that was stated.
By their numbers in this assay, from the lowest: compound 1; then compounds 3 and 2 (each within the scatter of the next).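

Among these compounds, compound 3 gives the first reading of a single change at this position: with the rest of compound 1 unchanged, 4-methoxyphenyl in place of 2,6-dimethylphenyl on the amide-type nitrogen gives a 4.2-fold higher number from compound 1 to compound 3 (0.62 log units; beyond the scatter) in this assay. The result shows that the group on this nitrogen is not interchangeable in this assay, even though the two groups have the same count of heavy atoms and each holds one six-membered aromatic ring of carbon only, the entering group adding one hydrogen-bond acceptor. Nothing available here ties the step to any particular feature of either group.

This one exchange replaces the two methyl groups and introduces the methoxy group together, so the compounds shown cannot separate the loss of the one from the gain of the other. As far as these compounds go, it also remains open how a chlorophenyl group or a pyridine ring on this nitrogen would compare, and whether the step keeps its size when the rest of compound 1 is changed.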